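A Ring Methyl Gives Way to Hydrogen

This account rests on a few compounds, and the source may have more. Where it says the series, first, only, none or still open, it means among the compounds named here.

Of the compounds shown here, three sharing one core have been tested so far in an ADME assay on MRC5 cells (Homo sapiens) for cytotoxicity, read by resazurin assay, with a stated time of 72 h (on this read-out lower numbers stand for stronger inhibition and higher numbers for weaker inhibition), for comparison. Compound 3 (`CC1(COCc2ccc(-c3ccc(F)cc3)cc2)CCn2cc([N+](=O)[O-])nc2O1`) gives > 64000 nM as a limit of the assay and not a number. Compound 1 (`O=[N+]([O-])c1cn2c(n1)OC(COc1cccc(-c3ccc(F)cc3F)n1)CC2`) likewise gives > 64000 nM as a limit of the assay. Compound 2 (`O=[N+]([O-])c1cn2c(n1)OC(COc1cnc(-c3ccc(F)cc3)nc1)CC2`) gives 62000 nM as a measured number. The position of compound 3 is therefore the limit of > 64000 nM in this assay, at which 2 of the 3 values shown sit, and no exact figure can be given for it.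

Compound 4 (`O=[N+]([O-])c1cn2c(n1)OC(COCc1ccc(-c3ccc(F)cc3)cc1)CC2`) differs from compound 3 by one change: hydrogen in place of methyl on a saturated ring carbon with hydrogen in place of methyl on a saturated ring carbon. Within the data shown here, no measured pair isolates this change. Among the measured compounds shown here, the expectation rests on compound 2 at 62000 nM as the only true number available, and no step beyond the scatter is expected in either direction in this assay here. The expected step of an at least 1.0-fold lower number from compound 3 to compound 4 (0.02 log units; that floor lies within the scatter) is therefore small. For compound 4 the estimated value is 60000 nM with an expected range from 30000 nM to 100000 nM and the reading may again be only a limit.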

Compound 4, half-maximal inhibitory concentration: > 64000 nM
Compound 4: no number, only a limit; the forecaster's own chance of this, stated with the estimate: 55%; at least 1.0-fold (0.02 log units) between middle value and limit.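

In this assay compound 4 gives > 64000 nM, a limit of the assay and not a number. Compound 3 is also only a limit, so no step can be read between compound 3 and compound 4. The compounds shown leave open whether hydrogen in place of methyl on a saturated ring carbon changes the read-out at all.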